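The compounds below may be only part of what the source reports. "The series", "measured", "known", "first", "only" and "open" are said of these compounds alone.

Of the compounds shown here, three have so far been measured in an assay on HEK293 cells for inhibition of acid ceramidase (Homo sapiens), read by fluorescence, with stated times of 10 min and 3 h; on this read-out lower numbers stand for stronger inhibition and higher numbers for weaker inhibition. Compound 1 `CC(C)N1CCN(c2ccc3c(c2)oc(=O)n3C(=O)NCCCCc2ccccc2)CC1` gives 211 nM. Compound 2 `CC(=O)N1CCc2oc(=O)n(C(=O)NCCCCc3ccccc3)c2C1` gives 293 nM, and compound 3 `CC(C)CNC(=O)n1c(=O)oc2ccc(C3CCN(C)CC3)cc21` gives 295 nM. Compound 1 holds the lowest of the three numbers, yet its gaps to compound 2 and to compound 3 both lie within the scatter of repeated measurements, so none of the three can be set apart from the others on these figures.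

Compound 4 `O=C(NCCCCc1ccccc1)n1c(=O)oc2cc(C3CCOCC3)ccc21` has not yet been measured. It differs from compound 1 in one place: oxan-4-yl in place of 4-isopropylpiperazin-1-yl on an aromatic carbon. The exchange sits on an aromatic carbon of the fused core shared by both compounds. Going by the values given here, no pair of measured compounds shows this exchange, so nothing in the data tells how large a step it brings or in which direction. The expectation is a small shift toward a higher number in this assay, around the edge of the scatter rather than clearly beyond it. Compound 4 is therefore expected to give about 400 nM, within a range from 150 nM to 1200 nM. The expected step is a 1.9-fold higher number from compound 1 to compound 4 (0.28 log units; within the scatter).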

Compound 4, half-maximal inhibitory concentration: 68 nM
Compound 4: the middle estimate sits 5.9-fold (0.77 log units) above what was measured, outside the stated range (below it).
By their numbers in this assay, from the lowest: compound 4; then compounds 1, 2 and 3 (each within the scatter of the next).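

Going by these compounds alone, this position on the shared core responds to the group it carries: in this assay, oxan-4-yl in place of 4-isopropylpiperazin-1-yl gives a 3.1-fold lower number from compound 1 to compound 4 (0.49 log units; beyond the scatter) and is the only step here that can be read between compounds differing in one place. The entering ring has fewer heavy atoms and one hetero atom rather than two, so the larger 4-isopropylpiperazin-1-yl group is not required at this position for inhibition at this level. Nothing at hand explains why the number falls.

On these data alone, with a single exchange at this position, it stays open whether the lower number follows from the loss of the nitrogen atoms, the smaller group, or both. Cyclohexyl or morpholin-4-yl at the same place would help separate these possibilities.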